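Shrinking the Cyclohexyl Ring on a Pyrimidine Cytotoxicity Series

A few compounds are considered here, and "the series" means these few. Any claim that something is new, unique, unknown or untested is made for them only; others in the source may bear on it.

Measured compounds:
- compound 1, `Cc1cc(NC2CCCCC2)nc(Nc2ccc(C#N)cc2)n1`: 340 nM
- compound 2, `Cc1cnc(Nc2ccc(C#N)cc2)nc1OC1CCCC1`: 9990 nM

Of the compounds shown here, two have been tested in an ADME assay on MT4 cells (Homo sapiens) for cytotoxicity, read by MTT assay; a lower number here means that less compound is tolerated, a higher number that more compound is tolerated. Compound 1 gives 340 nM, the lowest of the two numbers, so it is the less well tolerated one. Compound 2 gives 9990 nM, a far higher number, well beyond the scatter; as compound 2 differs from compound 1 in more than one place, the two values show only this gap and nothing about any single change.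

Compound 3, `Cc1cc(NC2CC2)nc(Nc2ccc(C#N)cc2)n1`, has not yet been measured. It differs from compound 1 in one place: cyclopropyl in place of cyclohexyl on a nitrogen on an aromatic ring. Among the compounds with values here, no measured pair shows this change, so the step from compound 1 to compound 3 can only be expected, not read off. The smaller ring is expected to push the number upward by a moderate amount, a 4.4-fold higher number from compound 1 to compound 3 (0.64 log units; beyond the scatter), beyond the scatter but far short of the gap to compound 2. Compound 3 is therefore estimated at 1500 nM, with a range from 400 nM to 6000 nM.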

Compound 3, half-maximal cytotoxic concentration: 88 nM
Estimate against measurement, compound 3: 17-fold (1.23 log units) above; measured number below the stated range.
By their numbers in this assay, from the lowest: compound 3; then compound 1; then compound 2.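

Putting cyclopropyl in place of cyclohexyl on a nitrogen on an aromatic ring gives, in this assay, a 3.9-fold lower number from compound 1 to compound 3 (0.59 log units; beyond the scatter), so the smaller group makes the compound less well tolerated, not better tolerated. Within the data shown here, this is the first change made at a single place, and it shows that this position alone can shift the number beyond the usual scatter, even though the ring shrinks from 6 heavy atoms to 3. No measurement here accounts for the drop.

A single pair cannot show whether the number follows ring size steadily, so a cyclobutyl ring at this position could fall anywhere relative to compound 1 and compound 3. From the compounds shown here alone, whether a ring is needed at all also remains open, as an open chain such as propyl would test.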